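Side-chain variation on the sulfur of the shared core

The source may hold more compounds than are shown below. What is called first, only, known or untested is meant among the compounds shown, and "the series" means these compounds.

Compound 1 `CC(C)c1n[nH]c2c(NCc3ccc(-c4ccccn4)cc3)nc(SC(C)C(C)O)nc12` is the reference point of this small set. In a functional assay on HT cells (Homo sapiens) for antiproliferative activity, read by fluorescence, with a stated time of 72 h (a lower number here means a stronger inhibitor of growth, a higher number a weaker inhibitor of growth), compound 1 gives 190 nM, the second highest of the three numbers measured. Its nearest neighbour is compound 3 `CCC(CO)Sc1nc(NCc2ccc(-c3ccccn3)cc2)c2[nH]nc(C(C)C)c2n1`, which gives 255 nM, a step of a 1.3-fold higher number from compound 1 to compound 3 (0.13 log units; within the scatter). The furthest is compound 2 `CC(C)c1n[nH]c2c(NCc3ccc(-c4ccccn4)cc3)nc(SCCCN)nc12`, which gives 120 nM, a step of a 1.6-fold lower number from compound 1 to compound 2 (0.20 log units; within the scatter). Between the two outer members the step is a 2.1-fold higher number from compound 2 to compound 3 (0.33 log units; beyond the scatter), so the whole set sits within a narrow window.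

Compound 4 `CSCCSc1nc(NCc2ccc(-c3ccccn3)cc2)c2[nH]nc(C(C)C)c2n1` differs from compound 1 only at the same sulfur: 2-(methylsulfanyl)ethyl in place of 2-hydroxy-1-methylpropyl on a sulfur. All three measured steps change the group on this sulfur and bear on the question; each of them stayed within or only just beyond the scatter. Among the compounds with values here, none of the measured compounds carries a chain without a hydrogen-bond donor, so the entering group has no direct precedent here, and the direction of any shift cannot be read from the data. The expectation is therefore a step of no more than modest size, a 1.4-fold higher number from compound 1 to compound 4 (0.14 log units; within the scatter). For compound 4 the estimate in this assay is 260 nM, with a range from 110 nM to 650 nM.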

Compound 4, concentration for 50% growth inhibition: 975 nM
Compound 4: the middle estimate sits 3.8-fold (0.57 log units) below what was measured; the whole stated range lies below it.
By their numbers in this assay, from the lowest: compounds 2, 1 and 3 (each within the scatter of the next, the first and the last beyond it); then compound 4.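

The group on this sulfur is less forgiving than the first three compounds suggested: in this assay the 2-(methylsulfanyl)ethyl chain gives a 5.1-fold higher number from compound 1 to compound 4 (0.71 log units; beyond the scatter) and a 3.8-fold higher number from compound 3 to compound 4 (0.58 log units; beyond the scatter) and an 8.1-fold higher number from compound 2 to compound 4 (0.91 log units; beyond the scatter) so compound 4 is the weakest inhibitor of growth of the four, with every step to it beyond the scatter. Across these four compounds the chains carrying a hydrogen-bond donor, in compounds 1, 2 and 3, stay close together while the entering chain, with 0 hydrogen-bond donors, stands apart, and no compound here goes against that pattern. The change also replaces oxygen with sulfur and alters the chain, and nothing available gives a measured reason for the loss in growth inhibition.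

The data leave open whether the shift follows the missing donor or the sulfur of the entering chain, since both change together in compound 4. A 2-methoxyethyl chain, a plain butyl chain and a 2-hydroxyethyl chain on the same sulfur would separate these readings and show whether branching plays any part.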